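The compounds below may be only part of what the source reports. "The series", "measured", "known", "first", "only" and "open" are said of these compounds alone.

Compound 1 `CC(C)OC(=O)C1=C(C(F)(F)F)NC(=O)NC1c1ccsc1` and compound 2 `CCOC(=O)C1=C(C(F)(F)F)NC(=O)NC1c1ccsc1` share one core, a ring bearing a trifluoromethyl group and an ester. In an assay on HEK293 cells for displacement of a labelled ligand from adenosine receptor A2b (Homo sapiens), read by radioligand binding, with a stated time of 30 min (a higher number here means a weaker inhibitor, a lower number a stronger inhibitor), compound 1 gives 651 nM and compound 2 gives 575 nM; the change between them, (hydrogen in place of methyl on a saturated chain carbon bound to an oxygen next to a carbonyl group and a saturated chain carbon), moved the number a 1.1-fold lower number from compound 1 to compound 2 (0.05 log units; within the scatter). Compound 3 `CC1=C(C(=O)OC(C)C(F)(F)F)C(c2ccoc2)NC(=O)N1` stands on a different core, and the difference between the two cores is not broken down here; in this assay compound 3 gives 234 nM. Compound 4 `CC1=C(C(=O)OCC(F)(F)F)C(c2ccoc2)NC(=O)N1` arises from compound 3 by the same change, (hydrogen in place of methyl on a saturated chain carbon bound to an oxygen next to a carbonyl group and a saturated chain carbon), at the same place. Because the earlier step of a 1.1-fold lower number from compound 1 to compound 2 (0.05 log units; within the scatter) stayed within the scatter, the step from compound 3 to compound 4 is expected to be small as well, about a 1.0-fold lower number from compound 3 to compound 4 (0.01 log units; within the scatter). Compound 4 is therefore estimated at 230 nM, most likely between 110 nM and 500 nM in this assay.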

Compound 4, inhibition constant: 588 nM
Compound 4: the middle estimate sits 2.6-fold (0.41 log units) below what was measured, outside the stated range (above it).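

In this assay, putting hydrogen in place of the methyl, which turns the 1-(trifluoromethyl)ethyl group into 2,2,2-trifluoroethyl, gives a 2.5-fold higher number from compound 3 to compound 4 (0.40 log units; beyond the scatter). The size of this step therefore did not carry over from the first pair of compounds to the second: the same change on two cores in this assay, a 1.1-fold lower number (0.05 log units; within the scatter) from compound 1 to compound 2 and a 2.5-fold higher number (0.40 log units; beyond the scatter) from compound 3 to compound 4, 2.8-fold (0.45 log units) apart, beyond the scatter of two such steps

The two pairs differ in more than one place, and the data do not tell which difference sets the steps apart, nor do two pairs give a rule for any further core. Still open, going by these compounds, is what happens on either core when a longer chain takes the place of the methyl. On these data alone, a carboxylic acid in place of the ester is equally open.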